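This account rests on a few compounds, and the source may have more. Where it says the series, first, only, none or still open, it means among the compounds named here.

Compound 1 `Cc1cnc(Nc2ccc(S(C)(=O)=O)cc2)nc1Nc1nc2ccc(F)cc2s1`: 3260 nM. Compound 2 `Cc1cnc(Nc2ccc(S(N)(=O)=O)cc2)nc1Nc1nc2ccc(Cl)cc2s1`: 8430 nM. Compound 3 `COc1ccc2nc(Nc3nc(Nc4ccc(S(N)(=O)=O)cc4)ncc3C)sc2c1`: a limit, > 50000 nM.

All three share one core and were tested in a functional assay on MCF7 cells (Homo sapiens) for antiproliferative activity, read by MTT assay, with a stated time of 48 h; a higher number here means a weaker inhibitor, a lower number a stronger inhibitor. Compound 1 gives 3260 nM and compound 2 gives 8430 nM. For compound 3 only the limit > 50000 nM is known, so it stands at the weak end of the numbers shown. Compound 3 sits at the limit of > 50000 nM in this assay, at which 1 of the 3 values shown sits. Compound 4 `Cc1cnc(Nc2ccc(S(N)(=O)=O)cc2)nc1Nc1nc2ccc(F)cc2s1` differs from compound 3 by fluoro in place of methoxy on an aromatic carbon. Within the data shown here, the one measured step that bears on this is an at least 5.9-fold higher number from compound 2 to compound 3 (0.77 log units; beyond the scatter), in which a methoxy replaced a chloro and the number rose past the range of the assay. Going the other way, from methoxy back to a halogen, the number is therefore expected to fall clearly. Compound 4 is expected at about 10000 nM, between 3000 nM and 40000 nM, an estimated step of an at least 5.0-fold lower number from compound 3 to compound 4 (0.69 log units; beyond the scatter).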

Compound 4, half-maximal inhibitory concentration: > 50000 nM
Compound 4 ended at the assay's limit; the forecaster's own chance of this, stated with the estimate: 15%; middle value at least 5.0-fold (0.69 log units) from the limit.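

With fluoro in place of chloro at this position, this assay shows an at least 5.9-fold higher number from compound 2 to compound 4 (0.77 log units; beyond the scatter), so here the two halogens do not behave alike. The sulfonyl group also matters, as amino in place of methyl on the sulfonyl sulfur gives an at least 15-fold higher number from compound 1 to compound 4 (1.18 log units; beyond the scatter). Compound 3 and compound 4 both rest at a limit, so the step between them cannot be read: the limit of > 50000 nM in this assay, at which 2 of the 4 values shown sit.

Open, going by these compounds, is how a bromo or a hydroxy group would fare at this position. Also open, on these data alone, is whether an ethyl group on the sulfonyl sulfur would keep a measurable value.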